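The compounds below may be only part of what the source reports. "The series", "measured", "known", "first", "only" and "open" are said of these compounds alone.

Measured compounds:
- compound 1 `N#Cc1ccc(CN[C@@H]2CN[C@H](C(=O)N3CCSC3)C2)cc1`, in an assay on a cell-free system (plasma) for inhibition of Dipeptidyl peptidase 4 (Rattus norvegicus), read by fluorescence (on this read-out lower numbers stand for stronger inhibition and higher numbers for weaker inhibition), compound 1 gives 34.3 nM
- compound 2 `CCOC(=O)CN(Cc1ccc(C#N)cc1)[C@@H]1CN[C@H](C(=O)N2CCSC2)C1`, in this assay compound 2 gives 15.3 nM

Among the measured compounds shown here, compound 2 holds the lowest of the two numbers so far; the only other number belongs to compound 1, and the step of a 2.2-fold lower number from compound 1 to compound 2 (0.35 log units; beyond the scatter) lies beyond the scatter, so compound 2 is the stronger inhibitor of the pair.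

The next compound, compound 3 `N#Cc1ccc(CN(CC(=O)O)[C@@H]2CN[C@H](C(=O)N3CCSC3)C2)cc1`, keeps the whole of compound 2 except at one place: hydrogen in place of ethyl on an oxygen next to a carbonyl group. For the measured compounds named here, nothing measured so far tests exactly this kind of change. Going by the values given here, the one known step, a 2.2-fold lower number from compound 1 to compound 2 (0.35 log units; beyond the scatter), concerns the arrival of the whole (ethoxycarbonyl)methyl group on the amine nitrogen, not the exchange of its ethyl for hydrogen, so it bears on compound 3 only loosely. Among the compounds with values here, with no closer precedent, the expected step of a 1.6-fold higher number from compound 2 to compound 3 (0.21 log units; within the scatter) is modest and of uncertain direction, most likely within the scatter. For compound 3 in this assay the estimate is 25 nM, with a range from 7 nM to 90 nM.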

Compound 3, half-maximal inhibitory concentration: 16.3 nM
For compound 3 the middle estimate is 1.5-fold (0.19 log units) above the measured one, and the stated range covers the measured number.
By their numbers in this assay, from the lowest: compounds 2 and 3 (each within the scatter of the next); then compound 1.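

In this assay, changing the (ethoxycarbonyl)methyl group to carboxymethyl gives a 1.1-fold higher number from compound 2 to compound 3 (0.03 log units; within the scatter) and so makes no readable difference: with ethyl or with hydrogen on the oxygen next to a carbonyl group, the two compounds cannot be told apart. Compared with hydrogen on the amine nitrogen, the carboxymethyl group gives a 2.1-fold lower number from compound 1 to compound 3 (0.32 log units; beyond the scatter) in this same assay, a modest step that is beyond the scatter and close to the one seen with the ethyl still in place, so at this position the ethyl is not needed to keep that step. No measurement on hand explains these results.

The compounds shown leave open whether the step on the amine nitrogen needs the carbonyl group at all, or whether a plain ethyl or a benzyl group there would give the same number. They also leave open how a longer chain ending in a carboxylic acid, or a chain ending in an amide or an amine, would read in this assay.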